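A few compounds are considered here, and "the series" means these few. Any claim that something is new, unique, unknown or untested is made for them only; others in the source may bear on it.

In a functional assay on HepG2 cells (Homo sapiens) for inhibition, read by MTT assay, with a stated time of 72 h (on this read-out higher numbers stand for weaker inhibition and lower numbers for stronger inhibition), three compounds built on one shared core have been measured. Compound 1 `O=C(Nc1ccccc1)C1CCN(C/C=C/c2ccccc2)CC1` gives 90900 nM. Compound 2 `CCc1ccc(NC(=O)C2CCN(C/C=C/c3ccccc3)CC2)cc1`, which carries an ethyl in place of hydrogen on an aromatic carbon, gives 23300 nM, and compound 3 `COc1ccccc1NC(=O)C1CCN(C/C=C/c2ccccc2)CC1`, with a methoxy in place of hydrogen on an aromatic carbon, gives 91200 nM. Compound 2 thus stands at the lowest of the three numbers: the first step is a 3.9-fold lower number from compound 1 to compound 2 (0.59 log units; beyond the scatter), the second is a 3.9-fold higher number from compound 2 to compound 3 (0.59 log units; beyond the scatter), while between the two flanking compounds there is a 1.0-fold higher number from compound 1 to compound 3 (0.00 log units; within the scatter).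

Compound 4 `O=C(Nc1nccs1)C1CCN(C/C=C/c2ccccc2)CC1` has not yet been measured in this assay. It differs from compound 2 in one place: 1,3-thiazol-2-yl in place of 4-ethylphenyl on an amide-type nitrogen. Among the compounds with values here, two measured steps bear on this. Within the data shown here, the ethyl that sets compound 2 apart from compound 1 accounts for a 3.9-fold lower number from compound 1 to compound 2 (0.59 log units; beyond the scatter), and its loss is part of the present change; the only other exchange of the whole group on the amide-type nitrogen gave a 3.9-fold higher number from compound 2 to compound 3 (0.59 log units; beyond the scatter). Among the measured compounds shown here, no measured compound carries a five-membered ring at this position, so the size of the new step is uncertain, but both precedents point toward a higher number. Compound 4 is therefore expected to give 80000 nM, within a range from 30000 nM to 200000 nM. This expected step of a 3.4-fold higher number from compound 2 to compound 4 (0.54 log units; beyond the scatter) would bring the number back to about where compound 1 sits.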

Compound 4, half-maximal inhibitory concentration: 22400 nM
Compound 4: middle estimate off by 3.6-fold (0.55 log units), on the high side; measured number outside the range, below it.
By their numbers in this assay, from the lowest: compounds 4 and 2 (each within the scatter of the next); then compounds 1 and 3 (each within the scatter of the next).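

In this assay the amide-type nitrogen takes a 1,3-thiazol-2-yl with no loss against the 4-ethylphenyl, with a 1.0-fold lower number from compound 2 to compound 4 (0.02 log units; within the scatter) as the step, so compound 2 and compound 4 cannot be told apart. The lower level therefore does not depend on the ethyl on a phenyl: measured against the plain phenyl, the change gives a 4.1-fold lower number from compound 1 to compound 4 (0.61 log units; beyond the scatter) and, against the 2-methoxyphenyl, it gives a 4.1-fold lower number from compound 3 to compound 4 (0.61 log units; beyond the scatter) with a size much like that of the first step. The two groups differ in ring size, in heavy atoms and in hydrogen-bond acceptors, yet these differences leave the number unmoved in this one pair, which is something the three phenyl compounds could not show.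

From the compounds shown here alone, it remains open whether the lower level follows from the sulfur, the ring nitrogen or the five-membered ring as such, and how a 1,3-oxazol-2-yl, a pyridin-2-yl, or a propyl chain in place of the ethyl would read at this position. No measurement shown here explains why these two groups end up level.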